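This account rests on a few compounds, and the source may have more. Where it says the series, first, only, none or still open, it means among the compounds named here.

Measured so far in an assay on isolated protein for inhibition of Amine oxidase [flavin-containing] A (Rattus norvegicus); on this read-out higher numbers stand for weaker inhibition and lower numbers for stronger inhibition:
- compound 1, `CCNCc1cn(Cc2ccccc2)c2ccccc12`: 262000 nM
- compound 2, `C#CCN(C)Cc1cc2ccccc2n1C`: 0.3 nM
- compound 3, `CC#CCN(C)Cc1cc2cc(OC)ccc2n1C`: 1.4 nM

Compound 2 gives the lowest number of the three. Compound 3 stands nearest to it, with a higher number that lies beyond the scatter, and compound 1 stands far away with a much higher number. Compound 1 carries neither the propargyl group nor a methyl on its amine nitrogen, and its structure differs from compound 2 in several places, so no single step can be read from that pair.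

Compound 4, `C#CCNCc1cc2ccccc2n1C`, has not been measured. Against compound 2 it shows (hydrogen in place of methyl on an amine nitrogen), that is, methyl(propargyl)amino becomes propargylamino.

Among the compounds with values here, no measured pair here isolates this change. A moderate weakening, beyond the scatter, is expected, a 3.3-fold higher number from compound 2 to compound 4 (0.52 log units; beyond the scatter). Compound 4 is thus estimated at 1 nM, in a range from 0.2 nM to 6 nM.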

Compound 4, inhibition constant: 240 nM
Compound 4: middle estimate off by 240-fold (2.38 log units), on the low side; the whole stated range lies below it.
By their numbers in this assay, from the lowest: compound 2; then compound 3; then compound 4; then compound 1.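

In this assay, hydrogen in place of methyl on the amine nitrogen gives an 800-fold higher number from compound 2 to compound 4 (2.90 log units; beyond the scatter), so this single carbon weighs heavily on inhibition. Within the data shown here, this is the first step that isolates one change, and it shows that this amine nitrogen is far from tolerant of change. Nothing shown here accounts for the size of this step.

Open, from the compounds shown here alone, is whether an isopropyl or cyclopropyl group on this amine nitrogen would hold the number near that of compound 2. Also open, going by these compounds, is whether the same loss follows on the core of compound 3.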